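The compounds below may be only part of what the source reports. "The series", "measured", "known", "first", "only" and "open" are said of these compounds alone.

In an ADME assay on a cell-free system (plasma, Homo sapiens) for metabolic stability (on this read-out higher numbers stand for a longer-lived compound and lower numbers for a shorter-lived compound), compound 3 `C[C@@H]1[C@H](C)[C@@H]1C(=O)N1C(=O)[C@@H](C)[C@@H]2[C@@H]1CCN2C(=O)[C@@H]1CCCN1S(=O)(=O)c1cccc2c(N(C)C)cccc12` gives 20 h. In this assay, compound 2 `C[C@@H]1C(=O)N(c2ccc([N+](=O)[O-])cc2)[C@H]2CCN(C(=O)OCc3ccccc3)[C@H]12` gives 40 h, and these two numbers lie within the usual scatter of each other. Compound 1 `C[C@@H]1C(=O)N(c2ccc([N+](=O)[O-])cc2[N+](=O)[O-])[C@H]2CCN(C(=O)OCc3ccccc3)[C@H]12` gives > 24 h, which is a limit of the assay and not a number. For the measured compounds named here, the only measured step, a step that the limit leaves unreadable from compound 1 to compound 2, therefore has no readable size. It also concerns hydrogen in place of nitro on an aromatic carbon, so it offers no size to carry over to the change considered here.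

Compound 4 `C[C@@H]1C(=O)N(C(=O)C2C(C)(C)C2(C)C)[C@H]2CCN(C(=O)[C@@H]3CCCN3S(=O)(=O)c3cccc4c(N(C)C)cccc34)[C@H]12` carries the difference (2,2,3,3-tetramethylcyclopropyl in place of 2,3-dimethylcyclopropyl on a carbonyl carbon), with 2,2,3,3-tetramethylcyclopropyl in place of 2,3-dimethylcyclopropyl on a carbonyl carbon. Going by the values given here, no measured step involves this kind of swap, so the best guide is compound 3 itself at 20 h, and no step beyond the scatter is expected in either direction. The expected step is no change at the digits printed from compound 3 to compound 4 (within the scatter). The estimate for compound 4 is 20 h, with an expected range from 9 h to 45 h.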

Compound 4, half-life: > 24 h
Compound 4: only a limit was reported (the forecaster's own chance of this, stated with the estimate: 30%); middle value at least 1.2-fold (0.07 log units) from the limit.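

Swapping 2,3-dimethylcyclopropyl for 2,2,3,3-tetramethylcyclopropyl on this carbonyl carbon gives the first readable step at this position in this assay, and it is an at least 1.2-fold higher number from compound 3 to compound 4 (0.07 log units; that floor lies within the scatter). Compound 4 gives > 24 h, which is a limit of the assay and not a number. The step therefore has only a floor, and the true size could lie anywhere from that floor upward, so the two extra-substituted ring does not show a shorter half-life, yet the result cannot say whether the gain goes beyond the scatter: the limit of > 24 h in this assay, at which 2 of the 4 values shown sit.

The compounds shown leave open how far past its limit compound 4 lies. They also leave open what an open chain such as a butyl group, an amine or a carboxylic acid would do on this carbonyl carbon.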